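A few compounds are considered here, and "the series" means these few. Any claim that something is new, unique, unknown or untested is made for them only; others in the source may bear on it.

The compounds here share a core in which an imidazoline-bearing side chain hangs from a benzene ring that carries a five-membered aromatic ring with a short chain on one nitrogen. Compound 1 is `CCn1ncnc1-c1ccccc1NCC1=NCCN1`, compound 2 is `CCCn1ncnc1-c1ccccc1NCC1=NCCN1`, and compound 3 is `Cn1nccc1-c1ccccc1NCC1=NCCN1`. In an in vitro functional assay on cells (Fibroblast) for agonist activity at Alpha-1A adrenergic receptor (Homo sapiens) (on this read-out higher numbers stand for an effect only at larger amounts of compound and lower numbers for an effect already at smaller amounts), compound 1 gives 1.26 nM, compound 2 gives 12.6 nM and compound 3 gives 10 nM. The difference between the cores of compound 1 and compound 3 is not broken down here.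

Among the compounds with values here, the one measured step is a 10-fold higher number from compound 1 to compound 2 (1.00 log units; beyond the scatter), made by the change (methyl in place of hydrogen on a saturated chain carbon, two bonds along the chain from an aromatic nitrogen).

Compound 4, `CCn1nccc1-c1ccccc1NCC1=NCCN1`, is not yet measured. It differs from compound 3 by methyl in place of hydrogen on a saturated chain carbon bound to an aromatic nitrogen. Within the data shown here, this is the same kind of change as the one from compound 1 to compound 2, but the place differs: there the carbon stood two bonds along the chain from an aromatic nitrogen, here it is bound to an aromatic nitrogen. Because the earlier step was a 10-fold higher number from compound 1 to compound 2 (1.00 log units; beyond the scatter), a step in the same direction but smaller is expected here, namely a 3.0-fold higher number from compound 3 to compound 4 (0.48 log units; beyond the scatter), giving for compound 4 an estimated 30 nM, between 8 nM and 120 nM.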

Compound 4, half-maximal effective concentration: 63.1 nM
Estimate against measurement, compound 4: 2.1-fold (0.32 log units) below, within the range that was stated.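

In this assay, methyl in place of hydrogen on a saturated chain carbon bound to an aromatic nitrogen gives a 6.3-fold higher number from compound 3 to compound 4 (0.80 log units; beyond the scatter), and this step can be set beside the earlier one on the other core: the same change on two cores in this assay, a 10-fold higher number (1.00 log units; beyond the scatter) from compound 1 to compound 2 and a 6.3-fold higher number (0.80 log units; beyond the scatter) from compound 3 to compound 4, 1.6-fold (0.20 log units) apart, within the scatter of two such steps. On these two cores, then, the change moves the number the same way and by sizes that cannot be told apart, so the earlier step was a fair guide to this one. This does not show that the change would carry to any other core, and since the added carbon sits at a different place on the chain in each pair, one pair of steps cannot separate the effect of the core from that of the place.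

The compounds shown leave open whether the number would keep climbing with a propyl chain on the core of compound 3. They also leave open how a branched isopropyl group, or a chain ending in a hydroxyl group or an amine, would behave on either core.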